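Capping one hydroxy group: what cytotoxicity might follow

A few compounds are considered here, and "the series" means these few. Any claim that something is new, unique, unknown or untested is made for them only; others in the source may bear on it.

Of the compounds shown here, three sharing one core have been tested in an ADME assay on THP-1 cells (Homo sapiens) for cytotoxicity; a higher number here means a weaker inhibitor, a lower number a stronger inhibitor. Compound 1 `COc1ccccc1-c1nnc(-c2ccc(C(=O)N/N=C/c3cccc(F)c3)cc2)o1` gives 353000 nM. Compound 2 `COc1ccccc1-c1nnc(-c2ccc(C(=O)N/N=C/c3ccc(O)c(O)c3)cc2)o1` gives 100000 nM, and compound 3 `COc1ccccc1-c1nnc(-c2ccc(C(=O)N/N=C/c3ccc(O)cc3O)cc2)o1` gives 104000 nM. Compound 3 thus stands second highest of the three numbers, close to compound 2 and well apart from compound 1: the step of a 1.0-fold higher number from compound 2 to compound 3 (0.02 log units; within the scatter) lies within the scatter, while the step of a 3.4-fold lower number from compound 1 to compound 3 (0.53 log units; beyond the scatter) is a modest drop, as is a 3.5-fold lower number from compound 1 to compound 2 (0.55 log units; beyond the scatter).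

Compound 4 `COc1ccc(/C=N/NC(=O)c2ccc(-c3nnc(-c4ccccc4OC)o3)cc2)c(O)c1` differs from compound 3 by methyl in place of hydrogen on an oxygen on an aromatic ring. For the measured compounds named here, no measured step covers exactly this change; the only steps that bear on it are those in which the hydroxy-bearing rings replaced the fluorophenyl of compound 1, and they lowered the number modestly. Capping one of the two hydroxy groups may partly undo that, so a small rise in this assay, near the edge of the scatter, is expected: a 1.4-fold higher number from compound 3 to compound 4 (0.16 log units; within the scatter). Compound 4 is estimated at 150000 nM, in a range from 70000 nM to 350000 nM.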

Compound 4, half-maximal inhibitory concentration: 308000 nM
Beside the measured number, compound 4's estimate is 2.1-fold (0.31 log units) below it, and the stated range covers the measured number.
By their numbers in this assay, from the lowest: compounds 2 and 3 (each within the scatter of the next); then compounds 4 and 1 (each within the scatter of the next).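

In this assay, putting a methyl on this oxygen, which turns 2,4-dihydroxyphenyl into 2-hydroxy-4-methoxyphenyl, is not a silent edit: the result is a 3.0-fold higher number from compound 3 to compound 4 (0.47 log units; beyond the scatter), a modest rise, and the comparison with the 3,4-dihydroxyphenyl compound gives a 3.1-fold higher number from compound 2 to compound 4 (0.49 log units; beyond the scatter), of similar size. Against the 3-fluorophenyl compound, the reading is a 1.1-fold lower number from compound 1 to compound 4 (0.06 log units; within the scatter), so one methyl is enough to cancel the drop seen with both dihydroxyphenyl rings. Among these four compounds, the lower numbers go with two free hydroxy groups, and no measurement available here explains this link.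

Still open, from the compounds shown here alone, is whether the rise comes from the added methyl or from the lost hydroxy hydrogen. Also open, going by these compounds, is how a longer chain such as ethyl on this oxygen, or an amine in place of the hydroxy group, would read.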